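From Methyl to Methylsulfanyl: Expecting Compound 3

The compounds below may be only part of what the source reports. "The series", "measured", "known", "first", "only" and "open" are said of these compounds alone.

Of the compounds shown here, two sharing one core have been measured in a functional assay on HEK293 cells for antagonist activity at transient receptor potential cation channel subfamily V member 1 (Rattus norvegicus), read by calcium flux; a higher number here means a weaker inhibitor, a lower number a stronger inhibitor. Within the data shown here, compound 1 `Clc1cccc(Cl)c1Nc1nc2c(Nc3ccccc3)ncnc2s1` gives 170 nM, while compound 2 `Cc1ccc(Nc2ncnc3sc(Nc4c(Cl)cccc4Cl)nc23)cc1` gives 32 nM, the lowest of the two numbers; the single step, a 5.3-fold lower number from compound 1 to compound 2 (0.73 log units; beyond the scatter), came from methyl in place of hydrogen on an aromatic carbon. Compound 3 `CSc1ccc(Nc2ncnc3sc(Nc4c(Cl)cccc4Cl)nc23)cc1` has not yet been measured. The change from compound 2 to compound 3 is methylsulfanyl in place of methyl on an aromatic carbon. Among the measured compounds shown here, the only step that bears on it is the one from compound 1 to compound 2, where placing a group at this position lowered the number beyond the scatter. A group of two heavy atoms now occupies the same position, so compound 3 is expected to stay near compound 2 or fall slightly, an estimated step of a 1.3-fold lower number from compound 2 to compound 3 (0.11 log units; within the scatter) in this assay. Compound 3 is therefore estimated at 25 nM, with a range from 8 nM to 80 nM.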

Compound 3, half-maximal inhibitory concentration: 12 nM
Estimate against measurement, compound 3: 2.1-fold (0.32 log units) above; the range from low to high includes it.
By their numbers in this assay, from the lowest: compound 3; then compound 2; then compound 1.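

In this assay, the result shows that this position is not exhausted once a hydrogen has been replaced: with the position already filled by methyl, exchanging that group for methylsulfanyl still gives a 2.7-fold lower number from compound 2 to compound 3 (0.43 log units; beyond the scatter), so the identity of the group matters as well as its presence. Counted from the unsubstituted phenyl of the series, methylsulfanyl gives a 14-fold lower number from compound 1 to compound 3 (1.15 log units; beyond the scatter), a larger drop than a 5.3-fold lower number from compound 1 to compound 2 (0.73 log units; beyond the scatter) seen with methyl. No measurement here accounts for the difference between the two groups.

The compounds shown leave open whether the lower number goes with the sulfur atom or simply with a second heavy atom, a question that methoxy or ethyl at this position would address. They also leave open whether a longer chain such as ethylsulfanyl would lower the number further or raise it again.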